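The source may report more compounds than this note shows. Statements on the series, on what has been measured and on what is new or still open speak of the compounds shown alone.

Of the compounds shown here, two built on one shared core have numbers so far in a functional assay with Homo sapiens as the target; on this read-out higher numbers stand for weaker inhibition and lower numbers for stronger inhibition. Compound 1 `CC(C)[C@H](NC(=O)COc1cccc2ccccc12)C(=O)N[C@@H](CC(=O)O)C(=O)COc1ccc(-c2ccccc2)cc1` gives 38700 nM, and compound 2 `CC(C)[C@H](NC(=O)COc1cccc2ccccc12)C(=O)N[C@@H](CC(=O)O)C(=O)COc1ccccc1C(F)(F)F` gives 17300 nM, the lower of the two numbers and so the stronger inhibition of this pair. Compound 3 `CC(C)[C@H](NC(=O)COc1cccc2ccccc12)C(=O)N[C@@H](CC(=O)O)C(=O)COc1ccc(C#N)cc1` has no number yet in this assay. It carries 4-cyanophenyl in place of the 2-(trifluoromethyl)phenyl of compound 2, on an oxygen on a saturated carbon: 4-cyanophenyl in place of 2-(trifluoromethyl)phenyl on an oxygen on a saturated carbon.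

Within the data shown here, only one measured step bears on this change. It is a 2.2-fold lower number from compound 1 to compound 2 (0.35 log units; beyond the scatter), a modest step beyond the scatter, made at the same place when 2-(trifluoromethyl)phenyl replaced 4-phenylphenyl. Among the measured compounds shown here, no measured compound carries 4-cyanophenyl, so the data give no firm direction for the new change. For the measured compounds named here, with that single modest step as the only guide, no step beyond the scatter is expected in this assay. The estimated step is a 1.3-fold higher number from compound 2 to compound 3 (0.10 log units; within the scatter). Compound 3 is expected to give about 22000 nM, with an estimated range from 9000 nM to 50000 nM.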

Compound 3, half-maximal inhibitory concentration: 26700 nM
Beside the measured number, compound 3's estimate is 1.2-fold (0.08 log units) below it; measured number inside the range.
By their numbers in this assay, from the lowest: compounds 2, 3 and 1 (each within the scatter of the next, the first and the last beyond it).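

In this assay the 4-cyanophenyl group of compound 3 stays within the scatter of both earlier groups on this oxygen. Replacing 2-(trifluoromethyl)phenyl gives a 1.5-fold higher number from compound 2 to compound 3 (0.19 log units; within the scatter), and cyano in place of phenyl on an aromatic carbon gives a 1.4-fold lower number from compound 1 to compound 3 (0.16 log units; within the scatter). The step beyond the scatter between the two earlier compounds is thus spanned by a compound that cannot be told apart from either of them, and a nitrile on the ring gives no separation from these two groups, while nothing on hand accounts for these numbers.

The change from compound 2 to compound 3 alters both the substituent and its place on the ring, so these compounds cannot separate the two contributions. It also remains open whether an unsubstituted phenyl, a saturated cyclohexyl, or an amine or carboxylic acid on the ring would move the number beyond the scatter in this assay, since all three groups shown here are substituted aromatic rings that carry no such function.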